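Series notes: the carbonyl substituent of compound 1 revisited

The source may hold more compounds than are shown below. What is called first, only, known or untested is meant among the compounds shown, and "the series" means these compounds.

Compound 1 `COc1cc(-c2nn(-c3cccc(NC(=O)c4ccc(Cl)c(C(F)(F)F)c4)c3)cc2-c2ccncc2)ccc1Cl` is the reference point here. In a functional assay on SK-MEL-5 cells (Homo sapiens) for inhibition, read by sulforhodamine B assay, with a stated time of 48 h (a higher number here means a weaker inhibitor of growth, a lower number a stronger inhibitor of growth), compound 1 gives 6870 nM, the highest of the three measured numbers. Compound 3 `COc1cc(-c2nn(-c3cccc(NC(=O)Nc4ccc(Cl)c(C(F)(F)F)c4)c3)cc2-c2ccncc2)ccc1Cl` gives 2890 nM, and compound 2 `O=C(Nc1cccc(-n2cc(-c3ccncc3)c(-c3ccc(Cl)c(O)c3)n2)c1)Nc1cc(C(F)(F)F)cc(C(F)(F)F)c1` gives 1250 nM; both lie beyond the scatter from compound 1. Within the data shown here, the only measured change made at the carbonyl carbon alone is a 2.4-fold lower number from compound 1 to compound 3 (0.38 log units; beyond the scatter). Compound 2 differs from compound 1 in more than one place, so its value is noted without a step.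

Compound 4 `COc1cc(-c2nn(-c3cccc(NC(=O)Nc4ccc(Cl)c(Cl)c4)c3)cc2-c2ccncc2)ccc1Cl` is not yet measured. It differs from compound 1 as follows: (3,4-dichlorophenyl)amino in place of 4-chloro-3-(trifluoromethyl)phenyl on a carbonyl carbon. Among the measured compounds shown here, this change contains the same switch from an aryl group to an arylamino group on the carbonyl carbon that the measured step above covered, but it also exchanges the halogen pattern on the entering ring, and no measured pair isolates that exchange. For the measured compounds named here, the expectation therefore rests on the one measured step, and a lowering of modest size is expected, a 2.3-fold lower number from compound 1 to compound 4 (0.36 log units; beyond the scatter). For compound 4 the estimated value is 3000 nM, expected to fall between 1200 nM and 7500 nM.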

Compound 4, concentration for total growth inhibition: 1490 nM
Compound 4: the middle estimate sits 2.0-fold (0.30 log units) above what was measured; low and high end bracket the measured number.
By their numbers in this assay, from the lowest: compounds 2, 4 and 3 (each within the scatter of the next, the first and the last beyond it); then compound 1.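

In this assay, chloro in place of trifluoromethyl on the entering ring, with the arylamino link kept, gives a 1.9-fold lower number from compound 3 to compound 4 (0.29 log units; within the scatter), so this halogen exchange cannot be told apart from the usual variation between repeats. The full change gives a 4.6-fold lower number from compound 1 to compound 4 (0.66 log units; beyond the scatter), which places both arylamino compounds beyond the scatter from the aryl compound, so among these three the lowering goes with the arylamino link under either ring pattern. No supporting information explains this lowering.

Going by these compounds, whether the amide hydrogen of the arylamino link matters remains open, as does how far a link of another kind would carry the same lowering, such as an oxygen atom or a methylene group. A ring bearing a nitrile or a methoxy group in place of the halogens also remains to be placed.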